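A Five-Membered Ring Replaces the Methoxyphenyl Group

The compounds below may be only part of what the source reports. "The series", "measured", "known", "first", "only" and "open" are said of these compounds alone.

Among the measured compounds shown here, compound 1 `COc1ccc(/C=N/NC(=S)NC(C)(C)[C@H]2CC=C(C)CC2)cc1` gives 43800 nM in a functional assay on NCI/ADR-RES cells (Homo sapiens) for inhibition, read by sulforhodamine B assay, with a stated time of 48 h (on this read-out higher numbers stand for weaker inhibition of growth and lower numbers for stronger inhibition of growth), the second highest of the three numbers measured so far. Compound 2 `CC1=CC[C@H](C(C)(C)NC(=S)N/N=C/c2ccccc2Cl)CC1` gives 75000 nM, a change of a 1.7-fold higher number from compound 1 to compound 2 (0.23 log units; within the scatter). Compound 3 `CC1=CC[C@H](C(C)(C)NC(=S)N/N=C/c2ccco2)CC1` gives 9800 nM, reached by a 4.5-fold lower number from compound 1 to compound 3 (0.65 log units; beyond the scatter) and by a 7.7-fold lower number from compound 2 to compound 3 (0.88 log units; beyond the scatter). Compound 4 `CC1=CC[C@H](C(C)(C)NC(=S)N/N=C/c2ccc[nH]2)CC1` differs from compound 1 by 1H-pyrrol-2-yl in place of 4-methoxyphenyl on a carbon with a double bond to nitrogen. Like furan-2-yl, the entering group is a five-membered aromatic ring with one hetero atom, so the two steps into compound 3 are the ones that bear on this change; both lowered the number beyond the scatter, though the hydrogen-bond donor of the entering ring has no measured counterpart here, which widens the range. A step of a 2.6-fold lower number from compound 1 to compound 4 (0.41 log units; beyond the scatter) is therefore expected. Compound 4 is estimated at 17000 nM, between 6000 nM and 50000 nM.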

Compound 4, concentration for 50% growth inhibition: 78000 nM
The estimate for compound 4 lay 4.6-fold (0.66 log units) below the measured number; measured number outside the range, above it.
By their numbers in this assay, from the lowest: compound 3; then compounds 1, 2 and 4 (each within the scatter of the next).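

The two five-membered rings do not behave alike at this position: 1H-pyrrol-2-yl in place of furan-2-yl raises the number (an 8.0-fold higher number from compound 3 to compound 4 (0.90 log units; beyond the scatter)), so a shared ring size and a single hetero atom do not carry the furan-2-yl result over. In this assay, 1H-pyrrol-2-yl instead stays level with the phenyl groups (a 1.8-fold higher number from compound 1 to compound 4 (0.25 log units; within the scatter); a 1.0-fold higher number from compound 2 to compound 4 (0.02 log units; within the scatter)), leaving compound 3 alone apart from the rest. Nothing measured here explains this gap between the two rings.

Still open, as far as these compounds go, is whether thiophen-2-yl, with sulfur as the ring hetero atom, would stand with compound 3 or with compound 4.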